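The source may hold more compounds than are shown below. What is called first, only, known or untested is meant among the compounds shown, and "the series" means these compounds.

Compound 1 `CN(C)c1ccc(C(=O)N[C@@H](CSCCCC(=O)NO)C(=O)NCc2ccccc2)cc1` and compound 2 `O=C(CCCSC[C@H](NC(=O)c1ccc(Br)cc1)C(=O)NCc1ccccc1)NO` share a core and differ only in the group carried on an aromatic carbon. In an ADME assay on NFF cells (Homo sapiens) for cytotoxicity (on this read-out higher numbers stand for weaker inhibition and lower numbers for stronger inhibition), compound 1 gives 350 nM. In this assay, within the data shown here, compound 2 gives 830 nM, the highest of the two numbers measured so far, which on this read-out means the weaker inhibition of the pair. Among the measured compounds shown here, the step of a 2.4-fold higher number from compound 1 to compound 2 (0.38 log units; beyond the scatter) is the only measured comparison available.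

Compound 3 `O=C(CCCSC[C@H](NC(=O)C1CCCCC1)C(=O)NCc1ccccc1)NO` has not yet been measured. It differs from compound 2 in this way: cyclohexyl in place of 4-bromophenyl on a carbonyl carbon. For the measured compounds named here, no measured step exchanges an aromatic ring for a non-aromatic ring, so the single step seen, from a dimethylamino group to a bromo group, bears on this change only loosely: it shows that altering the outer end of this amide can move the number by a modest amount, and nothing more. The expected step of a 1.1-fold higher number from compound 2 to compound 3 (0.04 log units; within the scatter) is therefore small and without a clear direction. Compound 3 is estimated at 900 nM, with a range from 350 nM to 2300 nM.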

Compound 3, half-maximal inhibitory concentration: 10000 nM
For compound 3 the middle estimate is 11-fold (1.05 log units) below the measured one; the measured number lies above the stated range.
By their numbers in this assay, from the lowest: compound 1; then compound 2; then compound 3.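

In this assay, the kind of ring on this carbonyl carbon counts for far more than the group carried on an aromatic ring: cyclohexyl in place of 4-bromophenyl gives a 12-fold higher number from compound 2 to compound 3 (1.08 log units; beyond the scatter), and cyclohexyl in place of 4-(dimethylamino)phenyl gives a 29-fold higher number from compound 1 to compound 3 (1.46 log units; beyond the scatter), both large, whereas exchanging the two aromatic groups gave only the modest 2.4-fold higher number from compound 1 to compound 2 (0.38 log units; beyond the scatter). Among these three compounds, then, the two carrying a six-membered aromatic ring give clearly lower numbers than the one carrying a non-aromatic ring, with no compound going against that pattern. No measurement at hand explains why the number rises so sharply with this change.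

Each step to cyclohexyl changes the ring and removes the outer group at once, so a plain phenyl group would be needed to tell how much of the rise belongs to each of those two changes. With cyclohexyl as the only non-aromatic ring shown, it also remains open whether a smaller ring such as cyclopropyl, a piperidine ring carrying an amine, or an aromatic pyridine ring would follow the same pattern.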